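Reversing the enone linker in a fused-ring chalcone series

The compounds below may be only part of what the source reports. "The series", "measured", "known", "first", "only" and "open" are said of these compounds alone.

Measured compounds:
compound 1, `COc1ccc(-c2cc(/C=C/C(=O)c3cc(OC)c(OC)c(OC)c3)nc3cc(-c4ccccc4)nn23)cc1OC`, 7200 nM
compound 2, `COc1ccc(C(=O)/C=C/c2cc(-c3ccc(OC)c(OC)c3)n3nc(-c4ccccc4)cc3n2)cc1OC`, 3900 nM
compound 3, `COc1ccc(C(=O)/C=C/c2cc(-c3ccc(OC)c(OC)c3)n3nc(-c4ccccc4)cc3n2)cc1`, 11900 nM

In a functional assay on A549 cells (Homo sapiens) for antiproliferative activity, read by MTT assay, with a stated time of 24 h (on this read-out higher numbers stand for weaker inhibition and lower numbers for stronger inhibition), compound 3 gives the highest of the three numbers. Its nearest neighbour is compound 1, a 1.7-fold higher number from compound 1 to compound 3 (0.22 log units; within the scatter), and the furthest is compound 2, a 3.1-fold higher number from compound 2 to compound 3 (0.48 log units; beyond the scatter). Between compounds 1 and 2 the step is a 1.8-fold lower number from compound 1 to compound 2 (0.27 log units; within the scatter).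

Compound 4, `COc1ccc(/C=C/C(=O)c2cc(-c3ccc(OC)c(OC)c3)n3nc(-c4ccccc4)cc3n2)cc1`, has the same atoms as compound 3 joined differently: (2-(4-methoxyphenyl)ethenyl)carbonyl in place of 2-((4-methoxyphenyl)carbonyl)ethenyl on an aromatic carbon. In all three measured compounds the carbonyl sits on the aryl side of the linker and the ethenyl on the shared core; compound 4 is the only one in which this is turned around. Among the measured compounds shown here, none of the measured steps touches the linker itself: they change only the methoxy pattern on the aryl ring, and each of those steps was small. For the measured compounds named here, no measured step therefore bears directly on the change from compound 3 to compound 4, and the expectation for this assay is a step of no clear direction, most likely within the scatter, a 1.0-fold higher number from compound 3 to compound 4 (0.00 log units; within the scatter). Compound 4 is estimated at 12000 nM, with a range from 4000 nM to 40000 nM.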

Compound 4, half-maximal inhibitory concentration: 19300 nM
Compound 4: the middle estimate sits 1.6-fold (0.21 log units) below what was measured; the measured number falls inside the stated range.
By their numbers in this assay, from the lowest: compounds 2, 1, 3 and 4 (each within the scatter of the next, the first and the last beyond it).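

In this assay, among the compounds shown here, the exchange of 2-((4-methoxyphenyl)carbonyl)ethenyl for (2-(4-methoxyphenyl)ethenyl)carbonyl, on the aromatic carbon next to the ring nitrogen, gives the only step here that reverses the linker itself (a 1.6-fold higher number from compound 3 to compound 4 (0.21 log units; within the scatter)). The earlier steps shown here changed only the methoxy pattern on the aryl ring, whereas this pair keeps the atoms and alters how they are joined, and the two orientations are not separated at this position. For the compounds shown here, this reading rests on the single pair with a 4-methoxyphenyl end, so it is a statement about compound 3 and compound 4 and not a rule for the series. No independent measurement bears on this result.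

Going by these compounds alone, whether the reversed linker behaves the same way with the 3,4-dimethoxyphenyl end of compound 2 or the 3,4,5-trimethoxyphenyl end of compound 1 remains open, which matters given that the methoxy pattern gave the one step beyond the scatter in the set. Also open, going by these compounds, is what an amide in place of the linker's ketone carbonyl, or a morpholine or carboxylic acid on the aryl ring, would do at this position.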